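Methoxy for Fluoro: Expected Cytotoxicity of Compound 4

The source may report more compounds than this note shows. Statements on the series, on what has been measured and on what is new or still open speak of the compounds shown alone.

Of the compounds shown here, three have been measured in a functional assay on C6 cells (Rattus norvegicus) for cytotoxicity, read by MTT assay, with a stated time of 24 h, tested at 6 ug/mL; on this read-out higher numbers stand for a weaker effect at the one concentration tested and lower numbers for a stronger effect. Compound 1 `O=C(CSc1ncccn1)N/N=c1/scc(-c2ccc(Br)cc2)n1-c1ccccc1` gives 76.4%, compound 2 `O=C(CSc1nnnn1-c1ccccc1)N/N=c1/scc(-c2ccccc2)n1-c1ccccc1` gives 52.1%, and compound 3 `Cc1nnc(SCC(=O)N/N=c2/scc(-c3ccc(F)cc3)n2-c2ccccc2)s1` gives 74.3%. On these numbers compound 3 stands second highest of the three: its nearest neighbour is compound 1, whose number lies within the scatter of that of compound 3, while compound 2 lies furthest away, beyond the scatter, with a lower number and thus a stronger effect at the one concentration tested.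

Compound 4 `COc1ccc(-c2cs/c(=N/NC(=O)CSc3nnc(C)s3)n2-c2ccccc2)cc1` has not yet been measured in this assay. It differs from compound 3 in one place: methoxy in place of fluoro on an aromatic carbon. Within the data shown here, no step between measured compounds of this set matches this change, so its effect on the read-out cannot be taken from the data. Among the measured compounds shown here, with compound 3 at 74.3% and no comparable step among the measured compounds, the step of a number 1.3 percentage points lower from compound 3 to compound 4 (within the scatter) in this assay is expected to stay within the scatter, in no particular direction. Compound 4 is therefore estimated to give 73% in this assay, with a range from 55% to 90%.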

Compound 4, a percentage reported as activity, at one concentration (the size of the read-out at that concentration, not a potency): 57.9%
The estimate for compound 4 lay 15.1 percentage points above the measured number, and the stated range covers the measured number.
By their numbers in this assay, from the lowest: compounds 2 and 4 (each within the scatter of the next); then compounds 3 and 1 (each within the scatter of the next).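

In this assay, the change from 4-fluorophenyl to 4-methoxyphenyl gives a number 16.4 percentage points lower from compound 3 to compound 4 (beyond the scatter), so the group at this place, on an aromatic carbon para to a large group, does bear on the read-out, with methoxy giving the stronger effect at the one concentration tested. Among these compounds, no two of the earlier compounds differed in one place, so none of them could show this. Nothing at hand accounts for the size or direction of this step.

As far as these compounds go, it remains open whether a hydroxy group, an amine or a plain methyl at this place would move the read-out as methoxy does. Also open, from the compounds shown here alone, is whether the same change would give a similar step with the other thioether side chains seen in compound 1 and compound 2.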